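A few compounds are considered here, and "the series" means these few. Any claim that something is new, unique, unknown or untested is made for them only; others in the source may bear on it.

Measured so far:
compound 1 `Cc1cccc(C#Cc2ccc3c(n2)CCN(C2CCCC2)C3=O)c1` — 7.5 nM
compound 2 `O=C1c2ccc(C#Cc3ccccc3)nc2CCN1C1CCCCC1` — 40 nM
compound 3 `Cc1ccccc1C#Cc1ccc2c(n1)CCN(C1CCCCC1)C2=O` — 466 nM

In a functional assay on HEK293 cells for positive allosteric modulation of metabotropic glutamate receptor 5 (Homo sapiens), read by FLIPR and calcium flux (a lower number here means that less compound is needed, a higher number that more compound is needed for the effect), compound 3 gives the highest number of the three. Nearest to it stands compound 2 with 40 nM, furthest compound 1 with 7.5 nM; both gaps lie beyond the scatter.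

Compound 4 `Cc1cccc(C#Cc2ccc3c(n2)CCN(C2CCCCC2)C3=O)c1` is the next compound. It differs from compound 3 in one place: 3-methylphenyl in place of 2-methylphenyl on a triple-bonded carbon. The two have the same atoms, joined differently.

For the measured compounds named here, one measured step bears on this change. a 12-fold higher number from compound 2 to compound 3 (1.07 log units; beyond the scatter) shows that adding the methyl in the position it holds in compound 3 costs a large step upward. Going by the values given here, compound 4 removes the methyl from that position and places it where compound 1 carries it; compound 1 differs from compound 4 elsewhere in the shared core, so no direct step is available, but with its methyl so placed compound 1 gives 7.5 nM, the lowest number of the set, and compound 2 without any methyl gives 40 nM.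

For compound 4 the expected step in this assay is therefore downward and large, about a 19-fold lower number from compound 3 to compound 4 (1.27 log units; beyond the scatter), undoing most of the rise seen on going from compound 2 to compound 3. The estimate for compound 4 is 25 nM, with a likely range from 8 nM to 80 nM.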

Compound 4, half-maximal effective concentration: 36 nM
For compound 4 the middle estimate is 1.4-fold (0.16 log units) below the measured one, and the stated range covers the measured number.
By their numbers in this assay, from the lowest: compound 1; then compounds 4 and 2 (each within the scatter of the next); then compound 3.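

In this assay, 3-methylphenyl in place of 2-methylphenyl on the triple-bonded carbon gives a 13-fold lower number from compound 3 to compound 4 (1.11 log units; beyond the scatter) and shows that the large penalty seen with compound 3 belongs to the 2-methylphenyl arrangement, not to the presence of a methyl as such. With the cyclohexyl group held constant, adding the methyl as in 3-methylphenyl gives a 1.1-fold lower number from compound 2 to compound 4 (0.05 log units; within the scatter) and so leaves compound 4 level with compound 2, which means that this methyl alone brings no measurable gain. The step of a 4.8-fold higher number from compound 1 to compound 4 (0.68 log units; beyond the scatter) for cyclohexyl in place of cyclopentyl on the amide-type nitrogen in a ring then places the low number of compound 1 with the cyclopentyl group, at least where the 3-methylphenyl group is present.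

The data carry no independent measurement that would explain why the two methylphenyl groups differ so sharply. On these data alone, it remains open whether chloro, methoxy or nitrile on the phenyl ring would follow the same pattern, and whether cyclobutyl or isopropyl on the amide-type nitrogen in a ring would extend the difference seen between cyclopentyl and cyclohexyl.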